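The source may hold more compounds than are shown below. What is called first, only, known or untested is meant among the compounds shown, and "the series" means these compounds.

Compound 2 `COc1ccc2c(=O)c(/C=C/C(=O)NCc3cccc(F)c3)coc2c1` carries a 3-fluorobenzyl group on the amide-type nitrogen of the shared core; in a functional assay on A549 cells (Homo sapiens) for inhibition, read by MTT assay, with a stated time of 48 h (on this read-out lower numbers stand for stronger inhibition and higher numbers for weaker inhibition), compound 2 gives 26900 nM. Compound 1 `COc1ccc2c(=O)c(/C=C/C(=O)Nc3ccccc3Cl)coc2c1` bears 2-chlorophenyl at that nitrogen, and in this assay compound 1 gives 29900 nM. Among the measured compounds shown here, these are the only two numbers so far, and the step of a 1.1-fold lower number from compound 1 to compound 2 (0.05 log units; within the scatter) is within the scatter, so neither compound stands apart from the other on these data.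

Compound 3 `COc1ccc2c(=O)c(/C=C/C(=O)Nc3ccccc3C)coc2c1` is not yet measured in this assay. It differs from compound 2 in one place: 2-methylphenyl in place of 3-fluorobenzyl on an amide-type nitrogen. For the measured compounds named here, the only measured step that concerns a change of the group on this nitrogen, a 1.1-fold lower number from compound 1 to compound 2 (0.05 log units; within the scatter), stayed within the scatter. Compound 3, like compound 1, carries a substituted phenyl rather than a benzyl on this nitrogen, and compound 1 lies within the scatter of compound 2. No further comparison is available. Compound 3 is therefore expected to show a step of a 1.0-fold higher number from compound 2 to compound 3 (0.02 log units; within the scatter), with no movement beyond the scatter. The estimate for compound 3 in this assay is 28000 nM, with a range from 12000 nM to 65000 nM.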

Compound 3, half-maximal inhibitory concentration: 23400 nM
The estimate for compound 3 lay 1.2-fold (0.08 log units) above the measured number; the measured number falls inside the stated range.
By their numbers in this assay, from the lowest: compounds 3, 2 and 1 (each within the scatter of the next).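

In this assay, 2-methylphenyl in place of 3-fluorobenzyl on the amide-type nitrogen gives a 1.1-fold lower number from compound 2 to compound 3 (0.06 log units; within the scatter), so a second exchange of the group at this position also stays within the scatter. Methyl in place of chloro on an aromatic carbon of the phenyl group gives a 1.3-fold lower number from compound 1 to compound 3 (0.11 log units; within the scatter), which is the first change shown on that phenyl group itself, and it too stays within the scatter. The three groups shown on this nitrogen are therefore not told apart by this read-out, a statement that holds for compounds 1, 2 and 3 only, and no other data bear on these results.

On these data alone, it remains open whether a group of another kind, such as an amine or a carboxylic acid on the aromatic ring, or a longer chain in place of the benzyl, would move the number beyond the scatter in this assay. Also open, as far as these compounds go, is how far a change elsewhere on the shared core, such as a hydroxyl in place of the methoxy, would shift the number.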